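Shortening the piperidine side chain of compound 3

The source may hold more compounds than are shown below. What is called first, only, known or untested is meant among the compounds shown, and "the series" means these compounds.

The measured compounds:
compound 1 `COc1cc2nc(/C=C/c3cccnc3)nc(N3CCC(CCNS(N)(=O)=O)CC3)c2cc1OC`, 86%
compound 2 `COc1ccccc1/C=C/c1nc(N2CCC(CCNS(N)(=O)=O)CC2)c2cc(OC)c(OC)cc2n1`, 74%
compound 3 `COc1cc2ncnc(N3CCC(CCNC(C)=O)CC3)c2cc1OC`, 9%

In an assay on cells for inhibition of Ectonucleotide pyrophosphatase/phosphodiesterase family member 1 (Homo sapiens), with a stated time of 60 min, tested at 1 uM (a higher number here means more inhibition at the concentration tested (going by the name of the read-out), a lower number less inhibition), compound 3 gives the lowest of the three numbers. Compound 2 stands nearer to it, and compound 1 furthest, both by margins beyond the scatter. Among the measured compounds shown here, the only step measured between two compounds, a number 12 percentage points lower from compound 1 to compound 2 (beyond the scatter), concerns the aryl group on the double-bonded chain and says nothing about the side chain on the piperidine.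

Compound 4 `COc1cc2ncnc(N3CCC(CC#N)CC3)c2cc1OC` differs from compound 3 by cyano in place of acetamidomethyl on a saturated chain carbon bound to a saturated ring carbon. For the measured compounds named here, no measured step touches this place, so the expectation rests on compound 3 alone. Compound 3 already sits near the bottom of the scale in this assay, with 9%, and there is little room below it. The step from compound 3 to compound 4 is therefore expected to be small, a number 2 percentage points lower from compound 3 to compound 4 (within the scatter), within the scatter. Compound 4 is estimated at 7%, with a range from 0% to 22%.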

Compound 4, a percentage reported as inhibition, at one concentration (the size of the read-out at that concentration, not a potency): < 1%
Compound 4 gave a limit, no number; the forecaster's own chance of this, stated with the estimate: 5%; middle value at least 6 percentage points away from the limit.
By their numbers in this assay, from the lowest: compound 3; then compound 2; then compound 1. At a limit, below all of these: compound 4.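

Putting cyano in place of acetamidomethyl on a saturated chain carbon bound to a saturated ring carbon gives, in this assay, a number at least 8 percentage points lower from compound 3 to compound 4 (that floor lies within the scatter). Compound 4 stands at a limit of the assay, not at a number: the limit of < 1% in this assay, at which 1 of the 4 values shown sits. This first look at the position shows that the cyanomethyl group, with no hydrogen-bond donor and fewer heavy atoms than 2-acetamidoethyl, brings no gain in inhibition at the concentration tested, though the pair cannot show a real loss beyond the scatter.

The compounds shown do not separate the shorter chain from the loss of the amide, as both change in this one step. They also leave open how an amine, a carboxylic acid or a longer chain ending in nitrile would read at this place, and whether cyano would read the same on the core of compound 1.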